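Trimming the Terminal Vinyl from a Diyne Ester

This account rests on a few compounds, and the source may have more. Where it says the series, first, only, none or still open, it means among the compounds named here.

The compounds share a diyne chain that ends in an oxygen-bearing carbon. Compound 1 `CCCCCCCC#CC#CCO` gives 5.9 ug/mL in a functional assay on HCT-15 cells (Homo sapiens) for cytotoxicity; a lower number here means that less compound is needed, a higher number that more compound is needed for the effect. Compound 2 `CCCCCCCC#CC#CCOCC(=O)O` gives 8.3 ug/mL in this assay, and a 1.4-fold higher number from compound 1 to compound 2 (0.15 log units; within the scatter) stays within the scatter. Compound 3 `C=CCCCCCCCC#CC#CCOCC(=O)OC` gives > 30 ug/mL in this assay, which is a limit of the assay rather than a number (the limit of > 30 ug/mL in this assay, at which 1 of the 3 values shown sits). Compound 4 `CCCCCCCC#CC#CCOCC(=O)OC` differs from compound 3 by hydrogen in place of vinyl on a saturated chain carbon, seven bonds along the chain from a triple-bonded carbon. Among the compounds with values here, no measured step covers this change; only a 1.4-fold higher number from compound 1 to compound 2 (0.15 log units; within the scatter), a change elsewhere on the chain, has been measured. Because compound 2 gives 8.3 ug/mL without any vinyl, compound 4 is expected at about 15 ug/mL, with a range from 5 ug/mL to 40 ug/mL. The step of an at least 2.0-fold lower number from compound 3 to compound 4 (0.30 log units; that floor lies within the scatter) is accordingly expected to lower the number, though compound 3 offers only a limit.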

Compound 4, concentration for half-maximal effect: 25.6 ug/mL
The estimate for compound 4 lay 1.7-fold (0.23 log units) below the measured number; measured number inside the range.
By their numbers in this assay, from the lowest: compounds 1 and 2 (each within the scatter of the next); then compound 4. At a limit, above all of these: compound 3.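

Vinyl to hydrogen gives an at least 1.1-fold lower number from compound 3 to compound 4 (0.06 log units; that floor lies within the scatter), so the part the vinyl plays on this saturated chain carbon stays unresolved in this assay. Compound 3 stands at a limit of the assay, not at a number: the limit of > 30 ug/mL in this assay, at which 1 of the 4 values shown sits. Compound 4 does give a number, and it shows what the methyl ester costs: a 3.1-fold higher number from compound 2 to compound 4 (0.49 log units; beyond the scatter) and a 4.3-fold higher number from compound 1 to compound 4 (0.64 log units; beyond the scatter), both modest.

The compounds shown leave open whether the vinyl would matter on the free alcohol or the acid. They also leave open how an amide or an amine would read in place of the methyl ester.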